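Replacing the 4-methoxyphenyl Group of Compound 3

The compounds below may be only part of what the source reports. "The series", "measured", "known", "first", "only" and "open" are said of these compounds alone.

Measured in a functional assay on HCT-116 cells (Homo sapiens) for antiproliferative activity, read by MTT assay, with a stated time of 72 h; on this read-out higher numbers stand for weaker inhibition and lower numbers for stronger inhibition:
- Compound 1 `O=C(CCc1cccc2c1B(O)OC2)Nc1cccc(Br)c1`: 1400 nM
- Compound 2 `O=C(CCc1cccc2c1B(O)OC2)Nc1cccc(-c2ccc(F)cc2)c1`: 550 nM
- Compound 3 `COc1ccc(-c2cccc(NC(=O)CCc3cccc4c3B(O)OC4)c2)cc1`: 160 nM

Compound 3 has the lowest number of the three, so it inhibits most strongly. Compound 4 `CSc1cccc(-c2cccc(NC(=O)CCc3cccc4c3B(O)OC4)c2)c1` carries 3-(methylsulfanyl)phenyl in place of 4-methoxyphenyl on an aromatic carbon, meta to a large group: 3-(methylsulfanyl)phenyl in place of 4-methoxyphenyl on an aromatic carbon. Two steps show gains when an aryl group replaces bromo: a 2.5-fold lower number from compound 1 to compound 2 (0.41 log units; beyond the scatter) and an 8.8-fold lower number from compound 1 to compound 3 (0.94 log units; beyond the scatter). A third shows that the group on that aryl ring matters: a 3.4-fold lower number from compound 2 to compound 3 (0.54 log units; beyond the scatter). Within the data shown here, no measured step tests sulfur for oxygen or a moved substituent. In this assay, a slight rise within the scatter is expected, with the estimated step being a 1.6-fold higher number from compound 3 to compound 4 (0.19 log units; within the scatter). The estimate for compound 4 is 250 nM, with an expected range of 80 nM to 800 nM.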

Compound 4, half-maximal inhibitory concentration: 110 nM
For compound 4 the middle estimate is 2.3-fold (0.36 log units) above the measured one, within the range that was stated.
By their numbers in this assay, from the lowest: compounds 4 and 3 (each within the scatter of the next); then compound 2; then compound 1.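

In this assay, 3-(methylsulfanyl)phenyl can stand in for 4-methoxyphenyl with no change beyond the scatter (a 1.5-fold lower number from compound 3 to compound 4 (0.16 log units; within the scatter)), so this position accepts sulfur for oxygen together with a moved substituent. The new group also keeps the gains over 4-fluorophenyl (a 5.0-fold lower number from compound 2 to compound 4 (0.70 log units; beyond the scatter)) and over bromo (a 13-fold lower number from compound 1 to compound 4 (1.10 log units; beyond the scatter)), showing that a substituent need not stay where compound 3 carries it. No evidence is available on why these numbers fall as they do.

Open, going by these compounds, is how sulfur and the changed place each count alone, and how an amine or a carboxylic acid on this aryl ring would read.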